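Trifluoromethoxy in place of iodo: expected cytotoxicity

The compounds below may be only part of what the source reports. "The series", "measured", "known", "first", "only" and "open" are said of these compounds alone.

Among the compounds with values here, the series so far holds three compounds that share one core and differ only in the group on the terminal aryl ring. Compound 1 `Cc1ccc(-n2nc(-c3ccc(C(F)(F)F)cc3O)nc2-c2ccccc2O)cc1` gives 94.1% in a functional assay on PC-12 cells (Rattus norvegicus) for cytotoxicity, read by MTT assay, with stated times of 2 h and 24 h, tested at 5 uM; a higher number here means a stronger effect of the compound at the concentration tested, a lower number a weaker effect. Compound 2 `CC(C)c1ccc(-n2nc(-c3ccc(C(F)(F)F)cc3O)nc2-c2ccccc2O)cc1` gives 100%, and compound 3 `Oc1cc(C(F)(F)F)ccc1-c1nc(-c2ccccc2O)n(-c2ccc(I)cc2)n1` gives 94.4%. Among these three numbers compound 3 stands second highest; its nearest neighbour is compound 1, separated by a number 0.3 percentage points higher from compound 1 to compound 3 (within the scatter), and its furthest is compound 2, separated by a number 5.6 percentage points lower from compound 2 to compound 3 (within the scatter). Both steps are within the scatter, and so is a number 5.9 percentage points higher from compound 1 to compound 2 (within the scatter), so the three compounds cannot be ordered on these data.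

The next compound, compound 4 `Oc1cc(C(F)(F)F)ccc1-c1nc(-c2ccccc2O)n(-c2ccc(OC(F)(F)F)cc2)n1`, changes the same position once more: trifluoromethoxy in place of iodo on an aromatic carbon. Within the data shown here, the steps that bear on it are the two exchanges at this aromatic carbon already measured, iodo for methyl and iodo for isopropyl, both of which stayed within the scatter. Nothing measured here points to a step beyond the scatter in either direction.

For compound 4 the expected value in this assay is 94%, with a range of 82% to 100%. The step from compound 3 that this estimate means is expected to be a number 0.4 percentage points lower from compound 3 to compound 4 (within the scatter).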

Compound 4, a percentage reported as activity, at one concentration (the size of the read-out at that concentration, not a potency): 84.9%
Compound 4: the middle estimate sits 9.1 percentage points above what was measured; the measured number falls inside the stated range.
By their numbers in this assay, from the lowest: compounds 4, 1, 3 and 2 (each within the scatter of the next, the first and the last beyond it).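

In this assay this aromatic carbon now gives its first step beyond the scatter, though a modest one (with trifluoromethoxy in place of isopropyl: a number 15.1 percentage points lower from compound 2 to compound 4 (beyond the scatter)). The two other new steps stay within the scatter (with trifluoromethoxy in place of iodo: a number 9.5 percentage points lower from compound 3 to compound 4 (within the scatter); with trifluoromethoxy in place of methyl: a number 9.2 percentage points lower from compound 1 to compound 4 (within the scatter)), so the change from 4-iodophenyl to 4-(trifluoromethoxy)phenyl cannot be read as a real shift, and the group at this place separates two compounds only at the ends of the series, isopropyl and trifluoromethoxy. Nothing measured alongside these numbers accounts for that single step beyond the scatter.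

The compounds shown leave open how an amine, a carboxylic acid or a longer alkyl chain at this aromatic carbon would read in this assay, and whether any such group would give a larger step than the one separating isopropyl from trifluoromethoxy. They also leave open whether that gap would persist at another concentration, or with a change elsewhere on the shared core.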